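This account rests on a few compounds, and the source may have more. Where it says the series, first, only, none or still open, it means among the compounds named here.

Two compounds share one core and differ only in the ring that sits on the amide-type nitrogen. Compound 1 `COc1ccc(NC(=O)c2csc(Cc3c(Cl)cccc3Cl)n2)cc1` carries a 4-methoxyphenyl there, and compound 2 `COc1ccc(NC(=O)c2csc(Cc3c(Cl)cccc3Cl)n2)cn1` carries a 6-methoxypyridin-3-yl. In an assay on CHO cells, read by calcium flux (a lower number here means a stronger inhibitor, a higher number a weaker inhibitor), compound 1 gives only a limit, > 4000 nM. In this assay compound 2 likewise gives only a limit, > 4000 nM. Among the measured compounds shown here, the single measured step, a step that the two limits leave unreadable from compound 1 to compound 2, cannot be read in size because of the limit of > 4000 nM in this assay, at which 2 of the 2 values shown sit. Compound 3 `O=C(Nc1cccc(Br)c1)c1csc(Cc2c(Cl)cccc2Cl)n1` keeps the same core and changes the ring once more: 3-bromophenyl in place of 6-methoxypyridin-3-yl on an amide-type nitrogen. For the measured compounds named here, no measured step bears on this change: the one step on record has no readable size, and the ring that enters, 3-bromophenyl, appears in no measured compound. With both measured compounds sitting at the limit of this assay, the expected step is a step that the limit leaves unreadable from compound 2 to compound 3, which is simply no movement that could be told apart from that limit. Compound 3 is therefore estimated at 5000 nM, with a range from 1500 nM to 20000 nM, and the assay is expected most likely to report only a limit again.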

Compound 3, half-maximal inhibitory concentration: > 4000 nM
Compound 3: a limit, no number; the forecaster's own chance of this, stated with the estimate: 70%; the middle value is on the limit's open side.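

Among the compounds shown here, no step between compound 1, compound 2 and compound 3 can be read in size, because all three give only a limit and no number: the limit of > 4000 nM in this assay, at which 3 of the 3 values shown sit. The compounds shown leave open whether any ring on the amide-type nitrogen of the shared core gives a readable value in this assay, and how these three rings truly compare.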